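The source may hold more compounds than are shown below. What is called first, only, known or untested is meant among the compounds shown, and "the series" means these compounds.

Measured in a functional assay on K562 cells (Homo sapiens), read by MTT assay, with a stated time of 72 h; on this read-out higher numbers stand for weaker inhibition and lower numbers for stronger inhibition
compound 1 `COc1ncnc2c1c(-c1cc3ccccc3o1)cn2[C@@H]1O[C@H](CO)[C@@H](O)[C@H]1O` gives 20900 nM
compound 2 `CN(C)c1ncnc2c1c(-c1ccsc1)cn2[C@@H]1O[C@H](CO)[C@@H](O)[C@H]1O` gives 530 nM

Compound 2 has the lower of the two numbers, and its gap to compound 1 lies beyond the scatter. Compound 3 `CN(C)c1ncnc2c1c(-c1cc3ccccc3o1)cn2[C@@H]1O[C@H](CO)[C@@H](O)[C@H]1O` is the next to be read, with this change from compound 2: 1-benzofuran-2-yl in place of thiophen-3-yl on an aromatic carbon in words, 1-benzofuran-2-yl in place of thiophen-3-yl on an aromatic carbon. Among the measured compounds shown here, the only measured compound carrying 1-benzofuran-2-yl is compound 1 at 20900 nM and it gives the weaker inhibition. The expected step is a 9.4-fold higher number from compound 2 to compound 3 (0.97 log units; beyond the scatter) toward weaker inhibition, beyond the scatter. For compound 3 the estimate is 5000 nM within an expected range of 1200 nM to 20000 nM in this assay.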

Compound 3, half-maximal inhibitory concentration: > 20000 nM
Compound 3 was reported as a limit; the forecaster's own chance of this, stated with the estimate: 10%; middle value at least 4.0-fold (0.60 log units) away from the limit.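

In this assay this aromatic carbon now has a comparison that changes one place only: with dimethylamino held constant, 1-benzofuran-2-yl in place of thiophen-3-yl gives an at least 37-fold higher number from compound 2 to compound 3 (1.57 log units; beyond the scatter) as a large loss of inhibition. Compound 3 gives > 20000 nM as a limit of the assay and not a number. The step between methoxy and dimethylamino therefore cannot be read: the limit of > 20000 nM in this assay, at which 1 of the 3 values shown sits.

Still open, going by these compounds, is how a phenyl or furan-3-yl group would read at this carbon. A methoxy partner for compound 2 would show whether thiophen-3-yl keeps its standing on that core.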